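A few compounds are considered here, and "the series" means these few. Any claim that something is new, unique, unknown or untested is made for them only; others in the source may bear on it.

Among the compounds with values here, compound 2, with the structure `Nc1cc(N)c2nc(-c3ccccc3)c(Oc3ccc(F)cc3)nc2c1`, is the one member of this small series for which a functional assay on DU-145 cells (Homo sapiens) for inhibition, read by sulforhodamine B assay, with a stated time of 48 h (a lower number here means a stronger inhibitor of growth, a higher number a weaker inhibitor of growth), gives a number: compound 2 gives 460 nM. Compound 1, with the structure `Nc1cc(N)c2nc(-c3ccccc3)c(Sc3ccc(F)cc3)nc2c1`, is reported in this assay only as a limit, < 100000 nM. Compound 3, with the structure `CCOC(=O)[C@H](CCC(=O)O)NC(=O)c1ccc(CNc2nc3cc(N)cc(N)c3nc2-c2ccccc2)cc1`, is likewise reported in this assay only as a limit, < 100000 nM. Within the data shown here, compound 2 therefore stands alone as the sole readable value, and the step that the limit leaves unreadable from compound 1 to compound 2 cannot be sized because the limit of < 100000 nM in this assay, at which 2 of the 3 values shown sit, leaves its starting point undefined.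

Compound 4, with the structure `COc1ccc(Sc2nc3cc(N)cc(N)c3nc2-c2ccccc2)cc1`, differs from compound 2 as follows: (4-methoxyphenyl)sulfanyl in place of 4-fluorophenoxy on an aromatic carbon. Among the measured compounds shown here, no measured step bears on this change in a readable way; the one step that touches the same position carries a limit. The expectation for compound 4 is thus uncertain, and the author expects a step of a 6.5-fold higher number from compound 2 to compound 4 (0.81 log units; beyond the scatter) in this assay toward weaker growth inhibition, with a wide range. Compound 4 is estimated to give 3000 nM in this assay, between 400 nM and 30000 nM.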

Compound 4, concentration for 50% growth inhibition: 16200 nM
Estimate against measurement, compound 4: 5.4-fold (0.73 log units) below; low and high end bracket the measured number.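

In this assay, the group on the aromatic carbon next to the ring nitrogen now has its first readable step, a 35-fold higher number from compound 2 to compound 4 (1.55 log units; beyond the scatter), and it runs toward weaker growth inhibition. Compound 1 is reported only as a limit, < 100000 nM. The steps from compound 1 to compound 2 and to compound 4 therefore stay unreadable, because they start from that limit: the limit of < 100000 nM in this assay, at which 2 of the 4 values shown sit.

The readable step changes the linking oxygen to sulfur and the fluoro to methoxy at once, and the compounds shown do not separate these two parts of the change. Going by these compounds, how a nitrile or a trifluoromethyl on that phenyl ring would read, with either link, remains open.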